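Amino in place of methoxy on the cyano compound

The source may hold more compounds than are shown below. What is called first, only, known or untested is meant among the compounds shown, and "the series" means these compounds.

Within the data shown here, in a functional assay on P388 cells (Mus musculus) for antiproliferative activity (on this read-out lower numbers stand for stronger inhibition and higher numbers for weaker inhibition), compound 1 `COc1ccc(S(=O)(=O)Nc2cccc3cc[nH]c23)cc1` gives 1.1 ug/mL and compound 2 `COc1ccc(S(=O)(=O)Nc2cccc3c(C#N)c[nH]c23)cc1` gives 0.17 ug/mL, the lower of the two numbers so far. Among the measured compounds shown here, the single measured step, a 6.5-fold lower number from compound 1 to compound 2 (0.81 log units; beyond the scatter), is cyano in place of hydrogen on an aromatic carbon.

Compound 3 `N#Cc1c[nH]c2c(NS(=O)(=O)c3ccc(N)cc3)cccc12` keeps that cyano group and differs from compound 2 at another place: amino in place of methoxy on an aromatic carbon, para to a large group (amino in place of methoxy on an aromatic carbon). For the measured compounds named here, no measured step involves a change at this place, and the step from cyano gives no direct guide to its size. With nothing to indicate a direction, no shift beyond the scatter is expected in this assay. The expected step is a 1.3-fold higher number from compound 2 to compound 3 (0.11 log units; within the scatter). For compound 3 the estimated value is 0.22 ug/mL, with an expected range of 0.07 ug/mL to 0.7 ug/mL.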

Compound 3, half-maximal inhibitory concentration: 0.72 ug/mL
The estimate for compound 3 lay 3.3-fold (0.51 log units) below the measured number; the measured number lies above the stated range.
By their numbers in this assay, from the lowest: compound 2; then compounds 3 and 1 (each within the scatter of the next).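

The place on an aromatic carbon, para to a large group, is not indifferent in this assay: amino in place of methoxy on the cyano compound gives a 4.2-fold higher number from compound 2 to compound 3 (0.63 log units; beyond the scatter) and so, of this pair, compound 2 with its methoxy keeps the lower number. This step runs in the opposite direction to a 6.5-fold lower number from compound 1 to compound 2 (0.81 log units; beyond the scatter) and shows that the cyano group does not by itself fix the level of the read-out, since a change elsewhere on the molecule still moves it beyond the scatter. Nothing at hand bears on the reason for this step.

The compounds shown leave open how other groups at this place, such as hydroxy, fluoro or dimethylamino, compare with methoxy and amino. They also leave open whether the same step would hold on the core of compound 1, which carries hydrogen in place of cyano.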